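A Hydroxymethyl Group on the Aromatic Nitrogen of Compound 1

The compounds below may be only part of what the source reports. "The series", "measured", "known", "first", "only" and "open" are said of these compounds alone.

Of the compounds shown here, three sharing a trimethoxyphenyl ketone framework have been measured in a functional assay on KB cells (Homo sapiens) for inhibition, with a stated time of 72 h (a higher number here means a weaker inhibitor, a lower number a stronger inhibitor), so far. Compound 1 (`COc1cc(C(=O)c2ccc3[nH]ccc3c2)cc(OC)c1OC`) gives 104 nM and holds the lowest number of the three. Compound 3 (`COc1cc(C(=O)c2cccc3cc[nH]c23)cc(OC)c1OC`) gives 310 nM in this assay and compound 2 (`COc1cc(C(=O)c2ccc3cc[nH]c3c2)cc(OC)c1OC`) gives 510 nM in the same test. Both lie beyond the usual scatter from compound 1, which makes compound 1 the strongest inhibitor of this small set.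

Compound 4 (`COc1cc(C(=O)c2ccc3c(ccn3CO)c2)cc(OC)c1OC`) keeps the core of compound 1 and differs in one place: hydroxymethyl in place of hydrogen on an aromatic nitrogen with hydroxymethyl in place of hydrogen on an aromatic nitrogen. Within the data shown here, no measured pair shows this kind of change, so the data offer no direct guide. A small move towards a higher number is expected in this assay since compound 1 at 104 nM already sits lowest. The estimated step of a 1.9-fold higher number from compound 1 to compound 4 (0.28 log units; within the scatter) is expected to lie near the edge of the scatter. Compound 4 is expected at 200 nM with an estimated range of 70 nM to 650 nM around that figure.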

Compound 4, half-maximal inhibitory concentration: 39 nM
The estimate for compound 4 lay 5.1-fold (0.71 log units) above the measured number; the whole stated range lies above it.
By their numbers in this assay, from the lowest: compound 4; then compound 1; then compounds 3 and 2 (each within the scatter of the next).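

In this assay the change from hydrogen to hydroxymethyl gives a 2.7-fold lower number from compound 1 to compound 4 (0.43 log units; beyond the scatter) and this modest step lies beyond the scatter. Compounds 1, 2 and 3 all carry that hydrogen on the aromatic nitrogen, so they said nothing about substitution there, whereas compound 4 shows that this position can carry a group while the number falls rather than rises. Nothing at hand bears on why the number falls.

The compounds shown leave open whether the drop belongs to hydroxymethyl itself or would also follow from another group on this nitrogen, such as a methyl group, a longer chain like hydroxyethyl, or an amine. They also leave open whether hydroxymethyl on the aromatic nitrogen of compound 2 or compound 3 would move the number the same way.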